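The compounds below may be only part of what the source reports. "The series", "measured", "known", "first", "only" and "open" are said of these compounds alone.

Compound 1, `CNc1nc(NC2(C#N)CCCCC2)nc(-n2cccn2)n1`, in an in vitro assay on Sf21 cells for inhibition of high affinity 3',5'-cyclic-AMP phosphodiesterase 7A (Homo sapiens) (a lower number here means a stronger inhibitor, a higher number a weaker inhibitor), gives only the limit > 5000 nM, not a number.
Compound 2, `CNc1nc(NC2(C#N)CCCCC2)nc(N2CCCC2)n1`, in this assay gives only the limit > 5000 nM.
Compound 3, `CNc1nc(NC2(C#N)CCCCC2)nc(-n2cnc(C#N)n2)n1`, in this assay gives only the limit > 5000 nM.

Compound 3 therefore stands at the limit of this assay, as do the two other measured compounds: the limit of > 5000 nM in this assay, at which 3 of the 3 values shown sit. Within the data shown here, the steps among them, a step that the two limits leave unreadable from compound 1 to compound 2, a step that the two limits leave unreadable from compound 1 to compound 3 and a step that the two limits leave unreadable from compound 2 to compound 3, are unreadable in size, so none of the measured steps gives a usable size for what follows.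

Compound 4, `CNc1nc(NC2CCCC2)nc(NC2(C#N)CCCCC2)n1`, is not yet measured. It differs from compound 3 in one place: cyclopentylamino in place of 3-cyano-1H-1,2,4-triazol-1-yl on an aromatic carbon. Among the measured compounds shown here, no measured step bears on this change with a readable size, so the direction and size of the step in this assay cannot be read from the data; the only guide is that every measured compound sits at the limit.

Compound 4 is therefore expected to give about 8000 nM in this assay, estimated to lie between 1500 nM and 40000 nM, most likely again reported as a limit. The estimate means an expected step that the limit leaves unreadable from compound 3 to compound 4.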

Compound 4, half-maximal inhibitory concentration: > 5000 nM
Compound 4: no number, only a limit; the forecaster's own chance of this, stated with the estimate: 70%; the middle value is on the limit's open side.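

Among these compounds, compound 4 also gives only a limit, so no step to it from compound 1, compound 2 or compound 3 can be read in this assay. All four compounds stand at the same point: the limit of > 5000 nM in this assay, at which 4 of the 4 values shown sit.

The compounds shown leave open how strongly each one actually inhibits, and whether any of the groups exchanged on the shared core makes a difference.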